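A few compounds are considered here, and "the series" means these few. Any claim that something is new, unique, unknown or untested is made for them only; others in the source may bear on it.

Of the compounds shown here, three with a shared core have been tested so far in a functional assay (aorta) with Rattus norvegicus as the target (a higher number here means that more compound is needed for the effect, a lower number that less compound is needed), and they show two levels. Compound 3 `COc1ccc(-c2nc(CN)sc2-c2ccc(OC)cc2)cc1` gives 7.7 uM and sits level with compound 2 `COc1ccc(-c2nc(CNC(C)=O)sc2-c2ccc(OC)cc2)cc1` at 8.1 uM within the scatter, while compound 1 `COc1ccc(-c2nc(/N=C(\N)[N+]3(C)CCCCC3)sc2-c2ccc(OC)cc2)cc1` stands higher at 21 uM on this scale. Compound 4 `COc1ccc(-c2nc(CNC(=O)N3CCOCC3)sc2-c2ccc(OC)cc2)cc1` has (morpholin-4-yl)carbonyl in place of hydrogen on an amine nitrogen of compound 3 ((morpholin-4-yl)carbonyl in place of hydrogen on an amine nitrogen). The closest guide is a 1.1-fold lower number from compound 2 to compound 3 (0.02 log units; within the scatter) for hydrogen in place of acetyl on that same nitrogen. The steps of a 2.6-fold lower number from compound 1 to compound 2 (0.41 log units; beyond the scatter) and a 2.7-fold lower number from compound 1 to compound 3 (0.44 log units; beyond the scatter) are modest, but they exchange a whole group on an aromatic carbon and so bear only loosely. No step beyond the scatter is therefore expected, though one acetyl example leaves room for surprise. An estimated 1.2-fold higher number from compound 3 to compound 4 (0.07 log units; within the scatter) is what this reasoning gives. Compound 4 is expected at about 9 uM with an estimated range from 3.5 uM to 23 uM in all.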

Compound 4, concentration for half-maximal effect: 12 uM
For compound 4 the middle estimate is 1.3-fold (0.12 log units) below the measured one; the measured number falls inside the stated range.
By their numbers in this assay, from the lowest: compounds 3, 2, 4 and 1 (each within the scatter of the next, the first and the last beyond it).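

In this assay, (morpholin-4-yl)carbonyl on the amine nitrogen gives a 1.6-fold higher number from compound 3 to compound 4 (0.19 log units; within the scatter) and morpholin-4-yl in place of methyl on the carbonyl carbon gives a 1.5-fold higher number from compound 2 to compound 4 (0.17 log units; within the scatter) so this nitrogen tolerates (morpholin-4-yl)carbonyl, not only acetyl, with no step beyond the scatter. The exchange of the whole group on the aromatic carbon gives a 1.8-fold lower number from compound 1 to compound 4 (0.24 log units; within the scatter) and, unlike the same exchange to compounds 2 and 3, stays within the scatter. Nothing available accounts for these small steps. From the compounds shown here alone, a sulfonyl group or a longer chain on this nitrogen remains open, so it is unknown whether any group here moves the number beyond the scatter.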